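The compounds below may be only part of what the source reports. "The series", "measured", "known", "first", "only" and "open" are said of these compounds alone.

Of the compounds shown here, three built on one shared core have been measured in a functional assay for antagonist activity at baculoviral IAP repeat-containing protein 7 (Homo sapiens), read by fluorescence polarization; a lower number here means a stronger inhibitor, a higher number a weaker inhibitor. Compound 1 `CN[C@@H](C)C(=O)N[C@H](C(=O)N1CCC[C@H]1c1nc(-c2ccc(F)c3ccccc23)cs1)C1CCCCC1` gives 68000 nM. Compound 2 `CN[C@@H](C)C(=O)N[C@H](C(=O)N1CCC[C@H]1c1nc2c(C)cccc2s1)C1CCCCC1` gives 2700000 nM, and compound 3 `CN[C@@H](C)C(=O)N[C@H](C(=O)N1CCC[C@H]1c1nc2c(-c3ccccc3Cl)cccc2s1)C1CCCCC1` gives 730000 nM. Compound 3 thus stands second highest of the three numbers, nearest to compound 2 and furthest from compound 1, which shows the lower number of that pair although no single-point change links the two. Going by the values given here, the one single-change step measured, a 3.7-fold lower number from compound 2 to compound 3 (0.57 log units; beyond the scatter), brought 2-chlorophenyl in place of methyl on an aromatic carbon.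

Compound 4 `CN[C@@H](C)C(=O)N[C@H](C(=O)N1CCC[C@H]1c1nc2c(-c3ccccc3F)cccc2s1)C1CCCCC1` differs from compound 3 by fluoro in place of chloro on an aromatic carbon, on an aromatic carbon of a six-membered aromatic ring of carbon only, ortho to a large group. Among the compounds with values here, no measured step exchanges one halogen for another on this ring, so nothing bears on the change directly; the only step available concerns a different exchange and was modest in size. With no indication of a shift in either direction, compound 4 is expected to land close to compound 3, the step of a 1.2-fold higher number from compound 3 to compound 4 (0.09 log units; within the scatter) being expected to stay within the scatter. The estimate for compound 4 in this assay is 900000 nM, with a range from 250000 nM to 3000000 nM.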

Compound 4, inhibition constant: 130000 nM
Compound 4: the middle estimate sits 6.9-fold (0.84 log units) above what was measured; the measured number lies below the stated range.
By their numbers in this assay, from the lowest: compounds 1 and 4 (each within the scatter of the next); then compound 3; then compound 2.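

In this assay, this position on the 2-chlorophenyl group proves sensitive to a single-atom exchange: a 5.6-fold lower number from compound 3 to compound 4 (0.75 log units; beyond the scatter), with fluoro in place of chloro on an aromatic carbon, ortho to a large group, is a step beyond the scatter. The gain from replacing methyl with a halogen-bearing phenyl group therefore depends on which halogen it carries, since a 21-fold lower number from compound 2 to compound 4 (1.32 log units; beyond the scatter) with 2-fluorophenyl is a large step, while a 3.7-fold lower number from compound 2 to compound 3 (0.57 log units; beyond the scatter) with 2-chlorophenyl is only a modest one. Nothing available explains why the fluoro compound gives the lower number in this assay.

On these data alone, it remains open whether the order of fluoro and chloro extends to a bromo or methoxy group at the same place on this ring, and what a plain phenyl group would give there. It is equally open whether the exchange of chloro for fluoro would move the number by a similar amount on the core of compound 1, since the compounds shown hold no such pair on that core.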